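Ring-fused amide series: hydroxy for trifluoromethyl on the anilide

The source may report more compounds than this note shows. Statements on the series, on what has been measured and on what is new or still open speak of the compounds shown alone.

Measured compounds:
compound 1, `O=C(Nc1ccccc1O)C1CCc2ccccc2N1C(=O)c1ccc(Cl)cc1`, 13400 nM
compound 2, `O=C(Nc1ccccc1C(F)(F)F)C1CCc2ccccc2N1C(=O)c1ccccc1`, 8120 nM

In a functional assay on NUGC-3 cells (Homo sapiens) for cytotoxicity, read by sulforhodamine B assay, with a stated time of 72 h (on this read-out lower numbers stand for stronger inhibition of growth and higher numbers for weaker inhibition of growth), compound 2 gives 8120 nM and compound 1 gives 13400 nM; the two values lie within the scatter of each other, so neither stands apart. Compound 3, `O=C(Nc1ccccc1O)C1CCc2ccccc2N1C(=O)c1ccccc1`, carries the change (hydroxy in place of trifluoromethyl on an aromatic carbon), hydroxy in place of trifluoromethyl on an aromatic carbon. Within the data shown here, no measured pair shows this step; compound 1 already carries the hydroxy group on a different benzoyl partner. The expected step of a 1.4-fold higher number from compound 2 to compound 3 (0.13 log units; within the scatter) is none beyond the scatter. Compound 3 is estimated at 11000 nM, range 4500 nM to 30000 nM.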

Compound 3, concentration for 50% growth inhibition: 3780 nM
Compound 3: the middle estimate sits 2.9-fold (0.46 log units) above what was measured; measured number below the stated range.
By their numbers in this assay, from the lowest: compound 3; then compounds 2 and 1 (each within the scatter of the next).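

In this assay hydroxy in place of trifluoromethyl on the aromatic carbon gives a 2.1-fold lower number from compound 2 to compound 3 (0.33 log units; beyond the scatter) with the unsubstituted benzoyl partner, so this position responds to the change. With the hydroxy held constant, hydrogen in place of chloro gives a 3.5-fold lower number from compound 1 to compound 3 (0.55 log units; beyond the scatter), so the benzoyl partner also affects the number. Nothing available explains either step. As far as these compounds go, it remains open whether a methoxy group or an amine at the same place would match hydroxy. Also open, from the compounds shown here alone, is whether the chloro effect holds with 2-(trifluoromethyl)phenyl on the amide.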